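Working notes on a small antiproliferative series

This account rests on a few compounds, and the source may have more. Where it says the series, first, only, none or still open, it means among the compounds named here.

compound 1 `Cc1cc(=O)oc2cc(SCc3ccncc3)ccc12`: in a functional assay on KBVIN cells (Homo sapiens) for antiproliferative activity, read by sulforhodamine B assay, with a stated time of 72 h (a higher number here means a weaker inhibitor of growth, a lower number a stronger inhibitor of growth), compound 1 gives only a limit, > 35200 nM.
compound 2 `Cc1cc(=O)oc2cc(SCc3cccc(C(F)(F)F)c3)ccc12`: in this assay compound 2 gives only a limit, > 28500 nM.
compound 3 `CCc1cc(=O)c2ccc(OC)c(CBr)c2o1`: in this assay compound 3 gives only a limit, > 33600 nM.

For the measured compounds named here, none of the three values is a number; each is a limit of this assay, so no measured step between compounds can be read. Compound 3 stands with the others at such a limit (the limit of > 33600 nM in this assay, at which 1 of the 3 values shown sits). Compound 4 `CCOc1ccc2c(=O)cc(CC)oc2c1CBr` differs from compound 3 by methyl in place of hydrogen on a saturated chain carbon bound to an oxygen on an aromatic ring; one bond further out, methoxy to ethoxy. Going by the values given here, no step between measured compounds sizes this change. The expectation is no step beyond the scatter in this assay, a step that the limit leaves unreadable from compound 3 to compound 4, with compound 4 most likely again reported as a limit. The estimate for compound 4 is 40000 nM, with a range from 15000 nM to 100000 nM.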

Compound 4, concentration for 50% growth inhibition: > 32100 nM
Compound 4 gave a limit, no number; the forecaster's own chance of this, stated with the estimate: 80%; the middle value lies beyond the limit too.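

For the compounds shown here, compound 3 and compound 4 both give only limits in this assay, and no step between them can be read. The compounds shown leave open how methoxy to ethoxy affects growth inhibition in this assay.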